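Swapping the Amide Group: Expected Gain for Compound 4

The source may hold more compounds than are shown below. What is called first, only, known or untested is meant among the compounds shown, and "the series" means these compounds.

Compound 1, `O=C(/C=C/c1ccncc1-c1ccc2ncccc2c1)N1CCOCC1`, gives 1590 nM in an assay on a protein complex for inhibition of CDK8/Cyclin C (Homo sapiens), with a stated time of 1 h; on this read-out higher numbers stand for weaker inhibition and lower numbers for stronger inhibition.
Compound 2, `Cn1ncc2cc(-c3cnccc3/C=C/C(=O)N3CCOCC3)ccc21`, gives 356 nM.
Compound 3, `CNC(=O)/C=C/c1ccncc1-c1ccc2c(cnn2C)c1`, gives 86.7 nM.

Compounds 2 and 3 share one core, while compound 1 carries a different core; the difference between the two cores is not broken down here. Within the shared core of compounds 2 and 3, the change methylamino in place of morpholin-4-yl on a carbonyl carbon produced a 4.1-fold lower number from compound 2 to compound 3 (0.61 log units; beyond the scatter). Compound 4, `CNC(=O)/C=C/c1ccncc1-c1ccc2ncccc2c1`, carries the same change made on compound 1: methylamino in place of morpholin-4-yl on a carbonyl carbon. The surroundings of the changed position read alike in both cases, so this is the same change, now on the core of compound 1. Among the measured compounds shown here, only one such step has been measured, so the expectation rests on it alone. Compound 4 is therefore expected to reach about 390 nM, a step of a 4.1-fold lower number from compound 1 to compound 4 (0.61 log units; beyond the scatter) that mirrors the earlier one, and this estimate rests on the step of a 4.1-fold lower number from compound 2 to compound 3 (0.61 log units; beyond the scatter) seen in this assay.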

Compound 4, half-maximal inhibitory concentration: 250 nM
Compound 4: middle estimate off by 1.6-fold (0.19 log units), on the high side; low and high end bracket the measured number.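

Methylamino in place of morpholin-4-yl on a carbonyl carbon again lowers the number, with a 6.4-fold lower number from compound 1 to compound 4 (0.80 log units; beyond the scatter) in this assay. Among the compounds shown here, this shows only that the change works in the same direction on these two cores; it does not show that it would do so on any other core, nor why the number falls. On these two cores, the size of the step carries over within the scatter: the same change on two cores in this assay, a 4.1-fold lower number (0.61 log units; beyond the scatter) from compound 2 to compound 3 and a 6.4-fold lower number (0.80 log units; beyond the scatter) from compound 1 to compound 4, 1.5-fold (0.19 log units) apart, within the scatter of two such steps

The compounds shown leave open whether an ethylamino group, with its longer chain, or a plain amino group would do better or worse than methylamino on the carbonyl carbon. They also leave open whether piperidin-1-yl would behave like morpholin-4-yl.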